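The compounds below may be only part of what the source reports. "The series", "measured", "known", "first", "only" and "open" are said of these compounds alone.

Two measured compounds share one core and differ only in the group attached to it. For the measured compounds named here, compound 1, `O=C1O/C(=C\Cn2cc(C(F)(F)F)c(=O)[nH]c2=O)C(OCc2ccccc2)=C1OCc1ccccc1`, carries a trifluoromethyl on an aromatic carbon of a six-membered aromatic ring with two nitrogens; in a functional assay on HeLa cells (Homo sapiens) for inhibition (on this read-out lower numbers stand for stronger inhibition and higher numbers for weaker inhibition), compound 1 gives 60000 nM, the only actual number among the values shown, and a number that already stands for weak inhibition. Compound 2, `O=C1O/C(=C\Cn2cnc3c(-n4cccc4)ncnc32)C(OCc2ccccc2)=C1OCc1ccccc1`, bears a different ring system in that place. In this assay compound 2 reaches only a limit of the assay, > 100000 nM, the reading described by the limit of > 100000 nM in this assay, at which 1 of the 2 values shown sits. The unmeasured compound 3, `O=C1O/C(=C\Cn2cc(I)c(=O)[nH]c2=O)C(OCc2ccccc2)=C1OCc1ccccc1`, differs from compound 1 by iodo in place of trifluoromethyl on an aromatic carbon: an iodo enters where the trifluoromethyl leaves. Going by the values given here, no measured step matches this change, so the expected step of a 1.2-fold lower number from compound 1 to compound 3 (0.08 log units; within the scatter) is small, within the usual scatter. Compound 3 is accordingly estimated at 50000 nM, with a range from 15000 nM to 150000 nM.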

Compound 3, half-maximal inhibitory concentration: 40000 nM
The estimate for compound 3 lay 1.3-fold (0.10 log units) above the measured number; the range from low to high includes it.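

Replacing trifluoromethyl (4 heavy atoms) with iodo (1 heavy atom) on this aromatic carbon gives a 1.5-fold lower number from compound 1 to compound 3 (0.18 log units; within the scatter) in this assay. This first measured step at the position shows that these two groups cannot be told apart on this read-out, despite their different heavy-atom counts, and that compound 3 still gives an actual number, 40000 nM, in the range that stands for weak inhibition. Compound 2 remains the only compound at a limit of the assay: the limit of > 100000 nM in this assay, at which 1 of the 3 values shown sits.

As far as these compounds go, whether an amine, a carboxylic acid or a longer chain on this carbon would shift the number beyond the scatter remains open. The compounds shown also leave open whether a change elsewhere on the shared core would matter more than this one.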